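Swapping the Ether Oxygen for Sulfur on a Dichlorophenyl Arm

The compounds below may be only part of what the source reports. "The series", "measured", "known", "first", "only" and "open" are said of these compounds alone.

Measured compounds:
- compound 1, `Nc1cc(N)c2nc(-c3ccccc3)c(Oc3ccc(Cl)c(Cl)c3)nc2c1`: 14500 nM
- compound 3, `COc1ccc(CNc2nc3cc(N)cc(N)c3nc2-c2ccccc2)cc1`: 27500 nM
- compound 2, `CCOC(=O)[C@H](CCC(=O)O)NC(=O)c1ccc(CNc2nc3cc(N)cc(N)c3nc2-c2ccccc2)cc1`: < 100000 nM (a limit of the assay, not a number)

All three compounds share one core and were tested in a functional assay on PC-3 cells (Homo sapiens) for inhibition, read by sulforhodamine B assay, with a stated time of 48 h; on this read-out lower numbers stand for stronger inhibition of growth and higher numbers for weaker inhibition of growth. Compound 1 gives 14500 nM and compound 3 gives 27500 nM; these two numbers lie within the scatter of each other, so neither can be called the stronger. For compound 2 the assay reports only a limit, < 100000 nM, and no number; this is the situation described by the limit of < 100000 nM in this assay, at which 1 of the 3 values shown sits.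

Compound 4 `Nc1cc(N)c2nc(-c3ccccc3)c(Sc3ccc(Cl)c(Cl)c3)nc2c1` is not yet measured. It differs from compound 1 in one place: (3,4-dichlorophenyl)sulfanyl in place of 3,4-dichlorophenoxy on an aromatic carbon. The change keeps the same count of heavy atoms, the same ring and the same acceptor count, and swaps only the linking atom. Among the compounds with values here, no measured pair with such a swap is available here, so the expectation rests on the size of the group staying the same. The step from compound 1 to compound 4 is expected to stay within the scatter, a 1.2-fold lower number from compound 1 to compound 4 (0.08 log units; within the scatter). Compound 4 is therefore estimated at 12000 nM, between 4000 nM and 40000 nM.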

Compound 4, concentration for total growth inhibition: 15500 nM
Estimate against measurement, compound 4: 1.3-fold (0.11 log units) below; low and high end bracket the measured number.
By their numbers in this assay, from the lowest: compounds 1, 4 and 3 (each within the scatter of the next).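

In this assay, setting (3,4-dichlorophenyl)sulfanyl in place of 3,4-dichlorophenoxy gives a 1.1-fold higher number from compound 1 to compound 4 (0.03 log units; within the scatter), so the two compounds cannot be told apart. This is the first pair shown that differs in one place, and it shows that at this aromatic carbon, next to the ring nitrogen, oxygen and sulfur can stand as the linking atom with no difference this read-out can separate. Nothing among the data shown bears on why the two linking atoms read alike.

Still open, on these data alone, is how a sulfonyl or a methylene link at this same carbon would read, since a swap of one linking atom says little about a larger change to the link. Also open, as far as these compounds go, is what an unsubstituted phenyl arm, without its two chlorine atoms, would give on the shared core.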